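Phenyl in place of methyl: compound 2 to compound 3

The source may report more compounds than this note shows. Statements on the series, on what has been measured and on what is new or still open speak of the compounds shown alone.

Compound 1 `CCN(CC)C(=S)SCC1=CCOC1=O` gives 136000 nM
Compound 2 `CCNC(=S)SCC1=CCOC1=O` gives 44400 nM

In a functional assay on EC9706 cells (Homo sapiens) for antiproliferative activity, read by MTT assay, with a stated time of 72 h (a lower number here means a stronger inhibitor, a higher number a weaker inhibitor), compound 2 holds the lower of the two numbers, at 44400 nM. The next compound, compound 3 `O=C1OCC=C1CSC(=S)NCc1ccccc1`, has not yet been measured. It differs from compound 2 by phenyl in place of methyl on a saturated chain carbon bound to an amide-type nitrogen, which is phenyl in place of methyl on a saturated chain carbon bound to an amide-type nitrogen. Among the compounds with values here, only one measured step bears on this change: a 3.1-fold lower number from compound 1 to compound 2 (0.49 log units; beyond the scatter). That step was modest and concerned the substituent on the amide-type nitrogen itself, so it guides the size only loosely. Within the data shown here, no measured compound carries a ring on this chain, so the direction remains uncertain. A similarly modest move toward a lower number is expected, given as a 2.2-fold lower number from compound 2 to compound 3 (0.35 log units; beyond the scatter). Compound 3 is estimated at 20000 nM, with an expected range from 6000 nM to 60000 nM.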

Compound 3, half-maximal inhibitory concentration: 34300 nM
Beside the measured number, compound 3's estimate is 1.7-fold (0.23 log units) below it, and the stated range covers the measured number.
By their numbers in this assay, from the lowest: compounds 3 and 2 (each within the scatter of the next); then compound 1.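

In this assay, phenyl in place of methyl on a saturated chain carbon bound to an amide-type nitrogen gives a 1.3-fold lower number from compound 2 to compound 3 (0.11 log units; within the scatter), so compound 2 and compound 3 cannot be told apart. The earlier compounds shown here showed only a change on the nitrogen itself, a 3.1-fold lower number from compound 1 to compound 2 (0.49 log units; beyond the scatter), which lay beyond the scatter; this result adds that, at this chain position, one six-membered aromatic ring of carbon only can enter in place of methyl with no readable difference in the number. No measurement at hand speaks to what lies behind this result.

The compounds shown leave open whether a longer chain carrying the phenyl, or a phenyl carrying a methoxy group, would move the number beyond the scatter. They also leave open whether a pyridine ring or an amine at this place would do so.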